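This account rests on a few compounds, and the source may have more. Where it says the series, first, only, none or still open, it means among the compounds named here.

Measured compounds:
Compound 1, `O=C1C(Nc2ccc(OC(F)(F)F)cc2)=CC(=O)c2ncncc21`, gives 900 nM in a functional assay on PANC-1 cells (Homo sapiens) for cytotoxicity, read by MTT assay, with a stated time of 72 h; a higher number here means a weaker inhibitor, a lower number a stronger inhibitor.
Compound 2, `CCc1ccc(-c2ccc(NC3=CC(=O)c4ncncc4C3=O)cc2)cc1`, gives 1200 nM in this assay.
Compound 3, `NC(=O)c1ccc(NC2=CC(=O)c3ncncc3C2=O)cc1`, gives 6300 nM in this assay.

Among these three, compound 3 has the highest number, that is, it is the weakest inhibitor: the step of a 7.0-fold higher number from compound 1 to compound 3 (0.85 log units; beyond the scatter) and the step of a 5.3-fold higher number from compound 2 to compound 3 (0.72 log units; beyond the scatter) both lie beyond the scatter. In each of those steps a carbamoyl took the place of another group on the same aromatic carbon, and each time the number rose by a modest amount.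

Compound 4, `O=C1C(Nc2ccc(Oc3ccccc3)cc2)=CC(=O)c2ncncc21`, is not yet measured. It differs from compound 3 in one place: phenoxy in place of carbamoyl on an aromatic carbon. This is the reverse kind of change to the two steps above: the carbamoyl leaves again, and a phenoxy, which carries an oxygen like the trifluoromethoxy of compound 1 and an aromatic ring like the 4-ethylphenyl of compound 2, enters. Both of those neighbours gave lower numbers than compound 3. A step in this assay of about the same size as those, but in the opposite direction, is therefore expected, meaning a clearly lower number for compound 4. The estimated step is a 5.7-fold lower number from compound 3 to compound 4 (0.76 log units; beyond the scatter). For compound 4 the expected value in this assay is 1100 nM, with a range from 500 nM to 2500 nM.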

Compound 4, half-maximal inhibitory concentration: 1800 nM
Compound 4: middle estimate off by 1.6-fold (0.21 log units), on the low side; the range from low to high includes it.
By their numbers in this assay, from the lowest: compounds 1, 2 and 4 (each within the scatter of the next); then compound 3.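

In this assay, phenoxy in place of carbamoyl gives a 3.5-fold lower number from compound 3 to compound 4 (0.54 log units; beyond the scatter) and so adds a third group, after trifluoromethoxy and 4-ethylphenyl, that lies clearly on the lower side of carbamoyl at this aromatic carbon. Among those three groups no difference stands out: phenoxy in place of 4-ethylphenyl gives a 1.5-fold higher number from compound 2 to compound 4 (0.18 log units; within the scatter) and phenyl in place of trifluoromethyl on the oxygen gives a 2.0-fold higher number from compound 1 to compound 4 (0.30 log units; within the scatter) within the same series. Across the four compounds shown, this position takes a phenoxy with its added aromatic ring, and only carbamoyl stands apart.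

As far as these compounds go, whether an amine or a carboxylic acid on this carbon would fall with carbamoyl or with the other three groups stays open. Nothing measured here explains why carbamoyl stands apart.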